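Swapping a Pentyl Chain for Propargyl on Two Cores

A few compounds are considered here, and "the series" means these few. Any claim that something is new, unique, unknown or untested is made for them only; others in the source may bear on it.

Compound 1 `CCCCCNc1nc(SC)nc(CCO)c1Cl` and compound 2 `C#CCNc1nc(SC)nc(CCO)c1Cl` share one core and differ only in this: ethynyl in place of butyl on a saturated chain carbon bound to a nitrogen on an aromatic ring. In an ADME assay on Vero cells (Chlorocebus sabaeus) for cytotoxicity, with a stated time of 48 h (on this read-out higher numbers stand for lower toxicity in this test and lower numbers for higher toxicity in this test), compound 1 gives 108000 nM, and compound 2 gives 485000 nM, so there is a 4.5-fold higher number from compound 1 to compound 2 (0.65 log units; beyond the scatter). Compound 3 `CCCCCNc1cc(CCO)nc(SC)n1` carries the same side chain as compound 1 on a second core; the two cores differ in this: hydrogen in place of chloro on an aromatic carbon. In this assay compound 3 gives 245000 nM, so there is a 2.3-fold higher number from compound 1 to compound 3 (0.36 log units; beyond the scatter). Among the compounds with values here, compound 4 `C#CCNc1cc(CCO)nc(SC)n1` is the unmeasured one; it differs from compound 3 in this: ethynyl in place of butyl on a saturated chain carbon bound to a nitrogen on an aromatic ring, the same kind of change as the one from compound 1 to compound 2, at the same place. Because the earlier step of a 4.5-fold higher number from compound 1 to compound 2 (0.65 log units; beyond the scatter) lay beyond the scatter, a step of broadly similar size is expected for compound 4, though this rests on a single pair and the cores are not the same. In this assay compound 4 is estimated to give 900000 nM, with a range from 400000 nM to 2000000 nM. That would mean an expected step of a 3.7-fold higher number from compound 3 to compound 4 (0.57 log units; beyond the scatter).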

Compound 4, half-maximal cytotoxic concentration: 1120000 nM
For compound 4 the middle estimate is 1.2-fold (0.09 log units) below the measured one; the range from low to high includes it.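

In this assay, the change from pentyl to propargyl on the second core gives a 4.6-fold higher number from compound 3 to compound 4 (0.66 log units; beyond the scatter), and that step matches the one on the first core: the same change on two cores in this assay, a 4.5-fold higher number (0.65 log units; beyond the scatter) from compound 1 to compound 2 and a 4.6-fold higher number (0.66 log units; beyond the scatter) from compound 3 to compound 4, 1.0-fold (0.01 log units) apart, within the scatter of two such steps. Hydrogen in place of chloro gives a 2.3-fold higher number from compound 2 to compound 4 (0.36 log units; beyond the scatter) with the propargyl chain, and it matches the step seen with the pentyl chain: the same change on two cores in this assay, a 2.3-fold higher number (0.36 log units; beyond the scatter) from compound 1 to compound 3 and a 2.3-fold higher number (0.36 log units; beyond the scatter) from compound 2 to compound 4, 1.0-fold (0.01 log units) apart, within the scatter of two such steps. Across these four compounds the two changes therefore behave independently, each moving the number towards lower toxicity in this test by the same amount whichever form the other place takes, but this is a single square of two side chains and two cores, so it shows neither that the pattern holds on other cores nor why it arises.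

Going by these compounds, it remains open whether a different chain, such as a longer chain or one ending in an amine or a carboxylic acid, would give the same step on both cores. On these data alone, it is equally open whether bromo in place of chloro would leave the propargyl step unchanged.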